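This account rests on a few compounds, and the source may have more. Where it says the series, first, only, none or still open, it means among the compounds named here.

Compound 1 `C(=N/Cc1cccnc1)\c1ccccc1` and compound 2 `C/C(=N\Cc1cccnc1)c1ccccc1` share one core and differ in a single place. In a functional assay on the whole organism (strain Swiss albino) with Mus musculus as the target, in the maximal electroshock model (a lower number here means that less compound is needed, a higher number that more compound is needed for the effect), compound 1 gives 53 mg/kg. In this assay, within the data shown here, compound 2 gives 55.7 mg/kg, and this number lies within the scatter of the one for compound 1, so the two cannot be told apart. Compound 3 `C/C(=N\Cc1cccnc1)c1cccc(N)c1` carries amino in place of hydrogen on an aromatic carbon. Among the measured compounds shown here, no measured pair shows the effect of such a change. The step expected here, a 1.1-fold lower number from compound 2 to compound 3 (0.05 log units; within the scatter), is small, in either direction or none beyond the scatter. Compound 3 is estimated at 50 mg/kg, between 25 mg/kg and 110 mg/kg.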

Compound 3, dose for half-maximal effect: 8.64 mg/kg
For compound 3 the middle estimate is 5.8-fold (0.76 log units) above the measured one; the measured number lies below the stated range.
By their numbers in this assay, from the lowest: compound 3; then compounds 1 and 2 (each within the scatter of the next).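

In this assay, amino in place of hydrogen on an aromatic carbon, meta to a large group, brings a 6.4-fold lower number from compound 2 to compound 3 (0.81 log units; beyond the scatter) and so shows that this position of the ring is not indifferent to substitution. Here, adding the amino group lowers the dose needed for the effect. Nothing at hand accounts for this shift. As far as these compounds go, whether a hydroxyl group, a methoxy group or a methylamino group at the same place would give a similar step remains open. So does whether amino on another carbon of that ring would do the same.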